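Swapping the benzyl substituent in a weakly cytotoxic series

The source may hold more compounds than are shown below. What is called first, only, known or untested is meant among the compounds shown, and "the series" means these compounds.

Among the measured compounds shown here, compound 2 `Cc1cc(-c2ccccc2)n(/C(N)=N/S(=O)(=O)c2cc(C)c(Cl)cc2SCc2cccc(C(F)(F)F)c2)n1` gives 19000 nM in a functional assay on HCT-116 cells (Homo sapiens) for cytotoxicity, read by MTT assay, with a stated time of 72 h (on this read-out higher numbers stand for weaker inhibition and lower numbers for stronger inhibition), the highest of the three numbers so far. Compound 3 `Cc1cc(S(=O)(=O)/N=C(\N)n2nccc2-c2ccccc2)c(SCc2cccc(C(F)(F)F)c2)cc1Cl` gives 14000 nM, and compound 1 `Cc1cc(S(=O)(=O)/N=C(\N)n2nccc2-c2ccccc2)c(SCc2cccc(Cl)c2)cc1Cl` gives 7000 nM. Compound 4 `Cc1cc(-c2ccccc2)n(/C(N)=N/S(=O)(=O)c2cc(C)c(Cl)cc2SCc2ccccc2Cl)n1` differs from compound 2 in one place: 2-chlorophenyl in place of 3-(trifluoromethyl)phenyl on a saturated chain carbon bound to a sulfur. The closest measured comparison is the step of a 2.0-fold higher number from compound 1 to compound 3 (0.30 log units; within the scatter), a related exchange of chloro and trifluoromethyl on the benzyl group that stays within the scatter; the step of a 1.4-fold lower number from compound 2 to compound 3 (0.13 log units; within the scatter) concerns a methyl on the core and also stays within the scatter. A small lower number in this assay is therefore expected, estimated as a 1.7-fold lower number from compound 2 to compound 4 (0.24 log units; within the scatter). Compound 4 is expected to give 11000 nM, with a likely range from 4000 nM to 30000 nM.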

Compound 4, half-maximal inhibitory concentration: 170000 nM
Estimate against measurement, compound 4: 15-fold (1.19 log units) below; measured number outside the range, above it.
By their numbers in this assay, from the lowest: compounds 1, 3 and 2 (each within the scatter of the next, the first and the last beyond it); then compound 4.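

In this assay, among the compounds shown here, the change to 2-chlorophenyl gives an 8.9-fold higher number from compound 2 to compound 4 (0.95 log units; beyond the scatter), the only change on the benzyl group so far that lies beyond the scatter, whereas the exchange of chloro and trifluoromethyl gave a 2.0-fold higher number from compound 1 to compound 3 (0.30 log units; within the scatter). The group on this saturated chain carbon bound to a sulfur can therefore move the number clearly towards weaker inhibition. Nothing available explains this step. Still open, going by these compounds, is what a plain benzyl group or a methoxy-bearing benzyl group would give, and whether 2-chlorophenyl acts the same way on the core of compound 3.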